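Positional chloro shift on the saturated ring carbon

The source may report more compounds than this note shows. Statements on the series, on what has been measured and on what is new or still open speak of the compounds shown alone.

Compound 3 `O=C(CNC(=O)c1ccccc1)NN1C(=O)CSC1c1ccc(Cl)cc1` is the most lipophilic of the three measured, giving 2.87 in a physicochemical assay for lipophilicity; a higher number here means a more lipophilic compound, a lower number a more polar compound; compound 1 `O=C(CNC(=O)c1ccccc1)NN1C(=O)CSC1c1ccc(O)cc1` gives 1.75 and compound 2 `O=C(CNC(=O)c1ccccc1)NN1C(=O)CSC1c1c[nH]c2ccccc12` gives 1.7. The steps into compound 3 were large: a number 1.12 log units higher from compound 1 to compound 3 (beyond the scatter) and a number 1.17 log units higher from compound 2 to compound 3 (beyond the scatter), while a number 0.05 log units lower from compound 1 to compound 2 (within the scatter). Compound 4 `O=C(CNC(=O)c1ccccc1)NN1C(=O)CSC1c1ccccc1Cl` differs from compound 3 only in where the chlorine sits: 2-chlorophenyl in place of 4-chlorophenyl on a saturated ring carbon. Among the measured compounds shown here, none of the measured steps moves a group around a ring; all exchange one group for another, so none bears directly on this change. No step beyond the scatter is therefore expected, with a number 0.12 log units lower from compound 3 to compound 4 (within the scatter) as the estimate. Compound 4 is estimated at 2.75, with a range from 2.4 to 3.1.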

Compound 4, partition coefficient: 2.3
Beside the measured number, compound 4's estimate is 0.45 log units above it; the whole stated range lies above it.
By their numbers in this assay, from the lowest: compounds 2 and 1 (each within the scatter of the next); then compound 4; then compound 3.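

Notes on the chlorine position: in this assay the same chlorophenyl group gives a different number depending only on where the chlorine sits, a number 0.57 log units lower from compound 3 to compound 4 (beyond the scatter), so at this saturated ring carbon the two isomers cannot be treated as interchangeable. The 2-chlorophenyl group still stands clear of the other two groups, a number 0.60 log units higher from compound 2 to compound 4 (beyond the scatter) and a number 0.55 log units higher from compound 1 to compound 4 (beyond the scatter), which places compound 4 between them and compound 3. Nothing available explains the shift.

As far as these compounds go, whether a methoxy group or a carboxylic acid would show a similar shift between these ring positions remains open. So does whether the shift holds on a different core.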